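Aryl replacement on the shared core: cytotoxicity notes

The source may report more compounds than this note shows. Statements on the series, on what has been measured and on what is new or still open speak of the compounds shown alone.

Three compounds have been measured in a toxicity assay on J774.A1 cells (Mus musculus) for cytotoxicity, read by SYBR Green assay, with a stated time of 1 h; a higher number here means that more compound is needed for the effect, a lower number that less compound is needed:
compound 1 `CN(C)c1ccc2cc(-c3ccccc3F)c(N)nc2c1`: 1600 nM
compound 2 `Cc1ccccc1-c1cc2ccc(N(C)C)cc2nc1N`: 6800 nM
compound 3 `CN(C)c1ccc2cc(-c3cccc(Cl)c3)c(N)nc2c1`: 13000 nM

Compound 1 stands lowest of the three numbers in this assay. Compound 2 is nearest to it, with a 4.3-fold higher number from compound 1 to compound 2 (0.63 log units; beyond the scatter), and compound 3 furthest, with an 8.1-fold higher number from compound 1 to compound 3 (0.91 log units; beyond the scatter); both steps lie beyond the scatter. Between the other two there is a 1.9-fold higher number from compound 2 to compound 3 (0.28 log units; within the scatter), which is within the scatter.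

Compound 4 `CN(C)c1ccc2cc(-c3ccccn3)c(N)nc2c1` differs from compound 1 in one place: pyridin-2-yl in place of 2-fluorophenyl on an aromatic carbon. Going by the values given here, no measured step brings a ring with a hetero atom into this group, so there is no direct precedent. The two steps that alter this group, a 4.3-fold higher number from compound 1 to compound 2 (0.63 log units; beyond the scatter) and an 8.1-fold higher number from compound 1 to compound 3 (0.91 log units; beyond the scatter), were both modest rises in this assay. A rise of similar size is therefore expected for compound 4, a 2.5-fold higher number from compound 1 to compound 4 (0.40 log units; beyond the scatter), although a result within the scatter of compound 1 cannot be excluded. The estimate for compound 4 in this assay is 4000 nM, with a range from 1500 nM to 12000 nM.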

Compound 4, half-maximal effective concentration: 2200 nM
Compound 4: middle estimate off by 1.8-fold (0.26 log units), on the high side; measured number inside the range.
By their numbers in this assay, from the lowest: compounds 1 and 4 (each within the scatter of the next); then compounds 2 and 3 (each within the scatter of the next).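

In this assay, pyridin-2-yl in place of 2-fluorophenyl gives a 1.4-fold higher number from compound 1 to compound 4 (0.14 log units; within the scatter), so the low end of the series is not confined to 2-fluorophenyl and also holds a ring with a hetero atom. The same ring stands clearly apart from the other two aryl groups, with a 5.9-fold lower number from compound 3 to compound 4 (0.77 log units; beyond the scatter) and a 3.1-fold lower number from compound 2 to compound 4 (0.49 log units; beyond the scatter), which shows that the aryl group at this position can separate the compounds in either direction. No supporting data bear on why these numbers fall as they do.

On these data alone, it remains open whether the low number goes with the ring nitrogen itself or with its place in the ring, a question that pyridin-3-yl or pyridin-4-yl would address. Also open, as far as these compounds go, is how this position responds to a non-aromatic group, such as morpholine or a simple amine.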